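Methyl for methoxy on the aryl ring of compound 2

The source may hold more compounds than are shown below. What is called first, only, known or untested is meant among the compounds shown, and "the series" means these compounds.

Compound 1 `Cn1nnnc1SCC(=O)N/N=C/c1ccccc1[N+](=O)[O-]` gives 1600000 nM in a functional assay on A549 cells (Homo sapiens) for cytotoxicity, read by XTT assay, with a stated time of 24 h; on this read-out lower numbers stand for stronger inhibition and higher numbers for weaker inhibition.
Compound 2 `COc1ccccc1/C=N/NC(=O)CSc1nnnn1C` gives 7000000 nM in this assay.

Among the measured compounds shown here, compound 2 holds the higher of the two numbers; the one measured step, a 4.4-fold higher number from compound 1 to compound 2 (0.64 log units; beyond the scatter), is a modest rise. Compound 3 `Cc1ccccc1/C=N/NC(=O)CSc1nnnn1C` differs from compound 2 by methyl in place of methoxy on an aromatic carbon. For the measured compounds named here, no measured step tries this exchange, and the methoxy-for-nitro step cannot be read across to it, so no direction is supported. Compound 3 is therefore expected to stay near compound 2 in this assay, at 5000000 nM with a range of 1500000 nM to 15000000 nM, a step of a 1.4-fold lower number from compound 2 to compound 3 (0.15 log units; within the scatter) that is estimated to lie within the scatter.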

Compound 3, half-maximal inhibitory concentration: > 10000000 nM
Compound 3 was reported as a limit (the forecaster's own chance of this, stated with the estimate: 25%); middle value at least 2.0-fold (0.30 log units) away from the limit.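

Compound 3 is reported only as a limit in this assay, > 10000000 nM. Methyl in place of methoxy gives an at least 1.4-fold higher number from compound 2 to compound 3 (0.15 log units; that floor lies within the scatter), so this exchange is not shown to move the number beyond the scatter, although its true size stays unknown. Methyl in place of nitro gives an at least 6.2-fold higher number from compound 1 to compound 3 (0.79 log units; beyond the scatter), which leaves compound 1, with its nitro group on this aromatic carbon, with the lowest number of the three. Still open, from the compounds shown here alone, is whether an amine or a carboxylic acid on this carbon would bring the number below that of compound 1.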